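From hydroxy to phenoxy on the shared core

A few compounds are considered here, and "the series" means these few. Any claim that something is new, unique, unknown or untested is made for them only; others in the source may bear on it.

For the measured compounds named here, in a functional assay on HT-29 cells (Homo sapiens) for inhibition, read by sulforhodamine B assay, with a stated time of 72 h (on this read-out higher numbers stand for weaker inhibition and lower numbers for stronger inhibition), compound 3 `CCOc1ccc(C2C(O)C(=O)N2c2cc(OC)c(OC)c(OC)c2)cc1` gives 15 nM, the lowest of the three numbers so far. Compound 2 `COc1ccc(C2C(Oc3ccccc3)C(=O)N2c2cc(OC)c(OC)c(OC)c2)cc1` stands at 52 nM and compound 1 `CCSc1ccc(C2C(Oc3ccccc3)C(=O)N2c2cc(OC)c(OC)c(OC)c2)cc1` at 632 nM.

Compound 4 `CCOc1ccc(C2C(Oc3ccccc3)C(=O)N2c2cc(OC)c(OC)c(OC)c2)cc1` departs from compound 3 at one place: phenyl in place of hydrogen on an oxygen on a saturated carbon. The same difference reads as hydroxy to phenoxy.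

Going by the values given here, no measured step covers this change directly. Among the compounds with values here, the only step available, a 12-fold lower number from compound 1 to compound 2 (1.08 log units; beyond the scatter), is large, but it is methoxy in place of ethylsulfanyl on an aromatic carbon, so it bears on the change only indirectly. It does show that numbers in the phenoxy compounds can move widely with a change elsewhere in the molecule. Both phenoxy compounds give higher numbers than compound 3, and the closer of the two, compound 2, gives 52 nM. That comparison also carries a second structural difference, so it is only a rough guide.

A moderate move towards weaker inhibition in this assay is therefore expected, and the estimated step is a 4.7-fold higher number from compound 3 to compound 4 (0.67 log units; beyond the scatter). For compound 4 the expected value is 70 nM, with an estimated range of 25 nM to 200 nM.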

Compound 4, half-maximal inhibitory concentration: 388 nM
Beside the measured number, compound 4's estimate is 5.5-fold (0.74 log units) below it; the whole stated range lies below it.
By their numbers in this assay, from the lowest: compound 3; then compound 2; then compounds 4 and 1 (each within the scatter of the next).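

Notes on the phenoxy position: in this assay, the change from hydroxy to phenoxy on the oxygen on a saturated carbon can now be read directly (a 26-fold higher number from compound 3 to compound 4 (1.41 log units; beyond the scatter)), and phenyl in place of hydrogen at this place goes with much weaker inhibition in the ethoxy compounds. With phenoxy held constant, the group on the aromatic carbon also moves the number: methyl in place of hydrogen on the saturated chain carbon bound to the aromatic oxygen gives a modest step (a 7.5-fold higher number from compound 2 to compound 4 (0.87 log units; beyond the scatter)), whereas ethoxy in place of ethylsulfanyl stays within the scatter (a 1.6-fold lower number from compound 1 to compound 4 (0.21 log units; within the scatter)), so those two groups are not separated in this phenoxy series. Nothing measured here accounts for the size of either the hydroxy-to-phenoxy step or the methyl step.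

Open is whether the hydroxy-to-phenoxy step has the same size with methoxy or ethylsulfanyl on the aromatic carbon, since only the ethoxy pair is shown. Also open, from the compounds shown here alone, is how an amine or a benzyl ether would read at this saturated carbon, where only hydroxy and phenoxy appear so far.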